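Replacing the distal ring with a five-membered heteroaromatic

A few compounds are considered here, and "the series" means these few. Any claim that something is new, unique, unknown or untested is made for them only; others in the source may bear on it.

Measured compounds:
compound 1 `CCC(C)(C)Cc1c[nH]c(CCc2ccc(-c3ccncc3)cc2)n1`: 305 nM
compound 2 `CCC(C)(C)Cc1c[nH]c(CCc2ccc(-c3cccnc3)cc2)n1`: 131 nM
compound 3 `CCC(C)(C)Cc1c[nH]c(CCc2ccc(-c3cccc(C#N)n3)cc2)n1`: 193 nM

All three share one core and differ only in the aromatic ring attached at its far end, and all were tested in a functional assay on HEK293 cells for agonist activity at Bombesin receptor subtype-3 (Homo sapiens), read by luminescence and calcium flux, with a stated time of 10 min; a lower number here means that less compound is needed, a higher number that more compound is needed for the effect. The number for compound 3 lies between those of the other two, and both gaps are within the scatter: a 1.5-fold higher number from compound 2 to compound 3 (0.17 log units; within the scatter) and a 1.6-fold lower number from compound 1 to compound 3 (0.20 log units; within the scatter). Among the measured compounds shown here, the only swap at this position that moved the number beyond the scatter was a 2.3-fold lower number from compound 1 to compound 2 (0.37 log units; beyond the scatter), and even that was modest.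

Compound 4 `CCC(C)(C)Cc1c[nH]c(CCc2ccc(-c3ccns3)cc2)n1` carries a different ring again: 1,2-thiazol-5-yl in place of 6-cyanopyridin-2-yl on an aromatic carbon. The three measured steps all bear on this change, since each replaces one ring with another at the same place, and none of them was large. On that basis no step beyond the scatter is expected, so a 1.0-fold higher number from compound 3 to compound 4 (0.02 log units; within the scatter) is the anticipated outcome. Compound 4 is therefore estimated at 200 nM, with a range from 80 nM to 500 nM.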

Compound 4, half-maximal effective concentration: 63 nM
Compound 4: middle estimate off by 3.2-fold (0.50 log units), on the high side; measured number outside the range, below it.
By their numbers in this assay, from the lowest: compound 4; then compounds 2, 3 and 1 (each within the scatter of the next, the first and the last beyond it).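

Compounds 1 to 3 suggested that swapping one ring for another at this position changes little, but the five-membered 1,2-thiazol-5-yl ring moves the number further in this assay than those swaps did. It gives a 3.1-fold lower number from compound 3 to compound 4 (0.49 log units; beyond the scatter) and a 2.1-fold lower number from compound 2 to compound 4 (0.32 log units; beyond the scatter) and also a 4.8-fold lower number from compound 1 to compound 4 (0.68 log units; beyond the scatter) with each step beyond the scatter, so compound 4 has the lowest number of the four. This swap changes the ring size and brings in sulfur together, these compounds cannot separate the two, and no measurement shown here accounts for the lower number.

On these data alone, whether other five-membered rings, such as thiophene or 1,2-oxazole, would also lower the number remains open. So does the effect of adding a methyl group or an amine to the 1,2-thiazol-5-yl ring.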